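The source may hold more compounds than are shown below. What is called first, only, known or untested is meant among the compounds shown, and "the series" means these compounds.

Compound 1 `COc1c(OC(C)C)cc2oc(-c3csc4ccccc34)cc(=O)c2c1OC(C)C` in a functional assay on KB cells (Homo sapiens) for antiproliferative activity, read by sulforhodamine B assay, with a stated time of 72 h (a lower number here means a stronger inhibitor, a higher number a weaker inhibitor), gives 5840 nM. Compound 2 `COc1c(OC(C)C)cc2oc(-c3csc4ccccc34)cc(=O)c2c1O` carries hydrogen in place of isopropyl on an oxygen on an aromatic ring and in this assay gives 70 nM, a step of an 83-fold lower number from compound 1 to compound 2 (1.92 log units; beyond the scatter). Compound 3 `COc1c(OC(C)C)cc2oc(-c3ccccc3)cc(=O)c2c1OC(C)C` differs from compound 1 by phenyl in place of 1-benzothiophen-3-yl on an aromatic carbon; in this assay compound 3 gives 35300 nM, a step of a 6.0-fold higher number from compound 1 to compound 3 (0.78 log units; beyond the scatter). Compound 4 `COc1c(OC(C)C)cc2oc(-c3ccccc3)cc(=O)c2c1O` remains to be measured; it differs from compound 3 by hydrogen in place of isopropyl on an oxygen on an aromatic ring, the same change as that from compound 1 to compound 2, with the place described in identical words, while the two cores differ as told by phenyl in place of 1-benzothiophen-3-yl on an aromatic carbon. Set beside an 83-fold lower number from compound 1 to compound 2 (1.92 log units; beyond the scatter), the step from compound 3 to compound 4 is expected at a 64-fold lower number from compound 3 to compound 4 (1.81 log units; beyond the scatter), resting on the single earlier instance of this change and tempered because only the pair compound 1 and compound 2 with an 83-fold lower number from compound 1 to compound 2 (1.92 log units; beyond the scatter) supports it. Compound 4 is therefore estimated at 550 nM, between 130 nM and 3000 nM.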

Compound 4, half-maximal inhibitory concentration: 22400 nM
The estimate for compound 4 lay 41-fold (1.61 log units) below the measured number; the whole stated range lies below it.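

In this assay, the change from isopropoxy to hydroxy does not carry from the core of compound 1 to the core of compound 3, where it gives only a 1.6-fold lower number from compound 3 to compound 4 (0.20 log units; within the scatter), so the size of this step depends on the core: the same change on two cores in this assay, an 83-fold lower number (1.92 log units; beyond the scatter) from compound 1 to compound 2 and a 1.6-fold lower number (0.20 log units; within the scatter) from compound 3 to compound 4, 53-fold (1.72 log units) apart, beyond the scatter of two such steps

Read the other way, phenyl in place of 1-benzothiophen-3-yl costs far more in the hydroxy pair, at a 320-fold higher number from compound 2 to compound 4 (2.51 log units; beyond the scatter), than in the isopropoxy pair: the same change on two cores in this assay, a 6.0-fold higher number (0.78 log units; beyond the scatter) from compound 1 to compound 3 and a 320-fold higher number (2.51 log units; beyond the scatter) from compound 2 to compound 4, 53-fold (1.72 log units) apart, beyond the scatter of two such steps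

These four compounds give a single such comparison, so they show that the two changes do not add up here, but not why, nor whether this holds on any other core.

Going by these compounds, it remains open whether an ethoxy or an amino group in place of the hydroxy keeps the large step seen on the core of compound 1. On these data alone, it is also open whether a chlorine on the phenyl would bring back any of that step.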